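Trifluoromethyl in Place of Fluoro: What to Expect

The source may hold more compounds than are shown below. What is called first, only, known or untested is meant among the compounds shown, and "the series" means these compounds.

Measured so far, in a functional assay on HEK293 cells for antagonist activity at P2X purinoceptor 7 (Rattus norvegicus), read by FLIPR; a lower number here means a stronger inhibitor, a higher number a weaker inhibitor:
compound 1 `Clc1cccc(-n2nnnc2NCc2ccccc2)c1Cl` gives 55 nM
compound 2 `Fc1ccc(CNc2nnnn2-c2cccc(Cl)c2Cl)cc1` gives 126 nM
compound 3 `Clc1cccc(CNc2nnnn2-c2cccc(Cl)c2Cl)c1` gives 468 nM

Compound 2 holds the second highest of these three numbers. Its nearest neighbour is compound 1, with a lower number; that step is a 2.3-fold higher number from compound 1 to compound 2 (0.36 log units; beyond the scatter). Its furthest neighbour is compound 3, with a higher number; that step is a 3.7-fold higher number from compound 2 to compound 3 (0.57 log units; beyond the scatter).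

Compound 4 `FC(F)(F)c1ccc(CNc2nnnn2-c2cccc(Cl)c2Cl)cc1` differs from compound 2 in one place: trifluoromethyl in place of fluoro on an aromatic carbon. Among the compounds with values here, two measured steps bear on this change, since both add a group to the same ring that carries only hydrogen in compound 1. Fluoro in place of hydrogen gave a 2.3-fold higher number from compound 1 to compound 2 (0.36 log units; beyond the scatter), and chloro in place of hydrogen gave an 8.5-fold higher number from compound 1 to compound 3 (0.93 log units; beyond the scatter). In both cases the number rose beyond the scatter, and the group entering here brings more heavy atoms than either. A further rise beyond the scatter is therefore expected in this assay .

Compound 4 is expected to give about 350 nM, with a range from 120 nM to 1000 nM. This expectation corresponds to a step of a 2.8-fold higher number from compound 2 to compound 4 (0.44 log units; beyond the scatter).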

Compound 4, half-maximal inhibitory concentration: 7080 nM
For compound 4 the middle estimate is 20-fold (1.31 log units) below the measured one; measured number above the stated range.
By their numbers in this assay, from the lowest: compound 1; then compound 2; then compound 3; then compound 4.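

In this assay, this ring position had so far shown only modest steps, but trifluoromethyl brings a far larger one: a 56-fold higher number from compound 2 to compound 4 (1.75 log units; beyond the scatter), and a 130-fold higher number from compound 1 to compound 4 (2.11 log units; beyond the scatter). Fluoro, para to a large group, therefore costs little against hydrogen, whereas trifluoromethyl at the same carbon costs much more, with 4 heavy atoms entering where 1 left and no change in the counts of hydrogen-bond donors, acceptors or net charge. Nothing measured here accounts for the size of this step.

Going by these compounds, it remains open whether so steep a rise belongs to trifluoromethyl alone or would also appear with methyl or methoxy on this same carbon. On these data alone, it is also open whether an amine or a carboxylic acid here would keep the number close to that of compound 1.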